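Working notes: phenyl in place of propyl in compound 2

The source may report more compounds than this note shows. Statements on the series, on what has been measured and on what is new or still open speak of the compounds shown alone.

In a functional assay on HepG2 cells (Homo sapiens) for antiproliferative activity, read by MTT assay, with a stated time of 3 days (a higher number here means a weaker inhibitor, a lower number a stronger inhibitor), compound 2 `CCCCCC#Cc1cn(C/C=C/CN2C(=O)c3ccccc3C2=O)c(=O)[nH]c1=O` gives 9000 nM and compound 1 `CCCCCc1ccc(C#Cc2cn(C/C=C\CN3C(=O)c4ccccc4C3=O)c(=O)[nH]c2=O)cc1` gives 18000 nM. These two values lie within the scatter of each other, so neither compound stands apart on the numbers available. The two compounds differ in more than one place, which leaves the series without a measured single-change step.

Compound 3 `O=C1c2ccccc2C(=O)N1C/C=C/Cn1cc(C#CCCc2ccccc2)c(=O)[nH]c1=O` departs from compound 2 in one place phenyl in place of propyl on a saturated chain carbon, two bonds along the chain from a triple-bonded carbon. Among the compounds with values here, no measured pair shows this change directly. The nearest guide is that compound 1 also carries a six-membered aromatic ring of carbon only in its side chain, and at 18000 nM it stays within the scatter of the value for compound 2.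

In this assay, no step beyond the scatter is therefore expected, in either direction. The estimated change is no change at the digits printed from compound 2 to compound 3 (within the scatter). For compound 3, the expected value is 9000 nM, with an estimated range of 3500 nM to 23000 nM.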

Compound 3, half-maximal inhibitory concentration: 7300 nM
Beside the measured number, compound 3's estimate is 1.2-fold (0.09 log units) above it, within the range that was stated.
By their numbers in this assay, from the lowest: compounds 3, 2 and 1 (each within the scatter of the next, the first and the last beyond it).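

In this assay, within the data shown here, phenyl in place of propyl on a saturated chain carbon, two bonds along the chain from a triple-bonded carbon, gives a 1.2-fold lower number from compound 2 to compound 3 (0.09 log units; within the scatter), and this is the only measured single-change step. At this position, a six-membered aromatic ring of carbon only and an open propyl end therefore read alike in this assay, which the earlier pair could not show because compound 1 and compound 2 differ in more than one place. No supporting measurement bears on why the two groups read alike.

On these data alone, both groups compared here are plain hydrocarbon with no net charge, so it remains open whether an amine, a carboxylic acid or a hydroxyl at this chain end would give a step beyond the scatter. Also open, as far as these compounds go, are a longer chain between the triple bond and the phenyl, and the effect of the double-bond geometry taken alone on the shared core.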